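Cyclopentylamino Gives Way to 4-Ethoxyphenylamino on the Shared Core

The compounds below may be only part of what the source reports. "The series", "measured", "known", "first", "only" and "open" are said of these compounds alone.

Measured so far:
compound 1 `O=C1C(NC2CCCC2)=CC(=O)c2c1nc1n2[C@H]2OC[C@@H](O)[C@H]2OC1` — > 16000 nM
compound 2 `O=C1C(N2CCCC2)=CC(=O)c2c1nc1n2[C@H]2OC[C@@H](O)[C@H]2OC1` — > 16000 nM

In a functional assay on HeLa cells (Homo sapiens) for inhibition, read by sulforhodamine B assay (a lower number here means a stronger inhibitor, a higher number a weaker inhibitor), compound 1 gives > 16000 nM, which is a limit of the assay rather than a number. Compound 2 also gives only a limit, > 16000 nM. The step that the two limits leave unreadable from compound 1 to compound 2 is therefore unreadable, since both compounds sit at the limit of > 16000 nM in this assay, at which 2 of the 2 values shown sit. Compound 3 `CCOc1ccc(NC2=CC(=O)c3c(nc4n3[C@H]3OC[C@@H](O)[C@H]3OC4)C2=O)cc1` differs from compound 1 by 4-ethoxyphenyl in place of cyclopentyl on an amine nitrogen. For the measured compounds named here, no measured step bears on this change, so the measured compounds give no direction for it. Compound 3 is expected to give 10000 nM, somewhere between 1500 nM and 40000 nM. That estimate means an expected step of an at least 1.6-fold lower number from compound 1 to compound 3 (0.20 log units; that floor lies within the scatter).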

Compound 3, half-maximal inhibitory concentration: 14400 nM
Compound 3: the middle estimate sits 1.4-fold (0.16 log units) below what was measured; low and high end bracket the measured number.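

In this assay, for the compounds shown here, compound 3 gives 14400 nM, the first real number at this position rather than a limit. Going by these compounds, the change to 4-ethoxyphenyl on the amine nitrogen amounts to an at least 1.1-fold lower number from compound 1 to compound 3 (0.04 log units; that floor lies within the scatter), so the true size of the step stays unknown and it may be no larger than ordinary scatter. The step from compound 1 to compound 2 still cannot be read: the limit of > 16000 nM in this assay, at which 2 of the 3 values shown sit.

On these data alone, it remains open what a plain phenyl or a 4-methoxyphenyl would give on the same amine nitrogen. That comparison would help separate the part played by the ring from that of the ethoxy group.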